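The source may report more compounds than this note shows. Statements on the series, on what has been measured and on what is new or still open speak of the compounds shown alone.

Measured in a functional assay on A-431 cells (Homo sapiens) for antiproliferative activity, read by MTT assay, with a stated time of 72 h; on this read-out higher numbers stand for weaker inhibition and lower numbers for stronger inhibition: compound 1 `C#Cc1cccc(Nc2ncnc3ccc(NC(=O)Nc4ccc(CN5CCN(C)CC5)cc4)cc23)c1` gives 2810 nM. Compound 2 `COC(=O)c1cccc(Nc2ncnc3ccc(NC(=O)Nc4ccc(CN5CCN(C)CC5)cc4)cc23)c1` gives 5630 nM.

Within the data shown here, compound 2 holds the higher of the two numbers, and its only neighbour, compound 1, sits within the scatter of it, as a 2.0-fold higher number from compound 1 to compound 2 (0.30 log units; within the scatter) shows. Compound 3 `CN1CCN(Cc2ccc(NC(=O)Nc3ccc4ncnc(Nc5cccc(C(=O)N6CCCC6)c5)c4c3)cc2)CC1` differs from compound 2 by pyrrolidin-1-yl in place of methoxy on a carbonyl carbon. Among the measured compounds shown here, the single measured step, a 2.0-fold higher number from compound 1 to compound 2 (0.30 log units; within the scatter), swapped the group on an aromatic carbon and stayed within the scatter; no measured step touches the carbonyl carbon. Compound 3 is expected to show no step beyond the scatter, a 1.1-fold lower number from compound 2 to compound 3 (0.05 log units; within the scatter), with an estimate of 5000 nM in a range from 1500 nM to 20000 nM.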

Compound 3, half-maximal inhibitory concentration: > 10000 nM
Compound 3 was reported as a limit (the forecaster's own chance of this, stated with the estimate: 5%); middle value at least 2.0-fold (0.30 log units) away from the limit.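

Compound 3 is reported only as a limit: the limit of > 10000 nM in this assay, at which 1 of the 3 values shown sits. The swap on the carbonyl carbon gives an at least 1.7-fold higher number from compound 2 to compound 3 (0.24 log units; that floor lies within the scatter), so this floor alone does not separate pyrrolidin-1-yl from methoxy, although the true step may be larger. Among these compounds, the change on the aromatic carbon from ethynyl to (pyrrolidin-1-yl)carbonyl gives an at least 3.5-fold higher number from compound 1 to compound 3 (0.55 log units; beyond the scatter), the first step here to pass the scatter, so the group at this place can matter on this read-out.

As far as these compounds go, how far compound 3 lies past its limit stays open. Also open, from the compounds shown here alone, is whether a simple amine or a hydroxyl, the latter giving a carboxylic acid, on the carbonyl carbon would read like compound 2 or like compound 3.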